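The source may hold more compounds than are shown below. What is called first, only, known or untested is meant among the compounds shown, and "the series" means these compounds.

Of the compounds shown here, two built on a shared core have so far been tested in an ADME assay on MDCK cells (Canis lupus familiaris) for cytotoxicity, read by microscopy, with a stated time of 72 h; a higher number here means that more compound is tolerated, a lower number that less compound is tolerated. Compound 1 `COC(=O)C[C@H](NC(=O)OC(C)(C)C)C(=O)N(Cc1ccc(F)cc1)C1(C(=O)NC2CCCCC2)CCN(Cc2ccccc2)CC1` gives 100000 nM in this assay. Compound 2 `COC(=O)C[C@H](NC(=O)OC(C)(C)C)C(=O)N(C)C1(C(=O)NCc2ccccc2)CCN(Cc2ccccc2)CC1` gives 20000 nM in this assay. Of these two numbers, compound 2 holds the lower one, and its gap to compound 1 is wider than the usual scatter of such measurements, so compound 2 is the less well tolerated of the pair. Compound 3 `COC(=O)C[C@H](NC(=O)OC(C)(C)C)C(=O)N(Cc1cccc(F)c1)C1(C(=O)NCc2ccccc2)CCN(Cc2ccccc2)CC1` has not yet been measured. It differs from compound 2 in a single place: 3-fluorophenyl in place of hydrogen on a saturated chain carbon bound to an amide-type nitrogen. Since compound 1, the better tolerated compound, also carries more than a methyl on that amide nitrogen, the added group may move compound 3 toward it. The step from compound 2 to compound 3 is therefore expected to raise the number, a 2.5-fold higher number from compound 2 to compound 3 (0.40 log units; beyond the scatter). For compound 3 in this assay the estimate is 50000 nM, with a range from 20000 nM to 100000 nM.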

Compound 3, minimum cytotoxic concentration: 47000 nM
Beside the measured number, compound 3's estimate is 1.1-fold (0.03 log units) above it; the measured number falls inside the stated range.
By their numbers in this assay, from the lowest: compound 2; then compound 3; then compound 1.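

For the compounds shown here, replacing methyl with 3-fluorobenzyl on the amide-type nitrogen is the only change here made in one place alone, and in this assay it gives a 2.4-fold higher number from compound 2 to compound 3 (0.37 log units; beyond the scatter). This shows that the group at this position can shift the number, with the larger group going along with more compound being tolerated, although the finding rests on this one pair. No measurement at hand explains the rise, so its reason remains unknown.

A plain benzyl group or a simple longer chain such as butyl at this position could help show whether the higher number goes with the aromatic ring, the fluorine or just a larger group. As far as these compounds go, it also remains open whether the same change would give a similar step on other versions of the shared core.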